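This account rests on a few compounds, and the source may have more. Where it says the series, first, only, none or still open, it means among the compounds named here.

Measured compounds:
Compound 1 `COc1ccc(N2C(=O)N(Cc3c(F)cc(F)cc3OC)c3ccccc3S2(=O)=O)cc1OC` gives 63.1 nM in an assay on isolated protein for displacement of a labelled ligand from Orexin/Hypocretin receptor type 1 (Homo sapiens), with a stated time of 90 min; on this read-out lower numbers stand for stronger inhibition and higher numbers for weaker inhibition.
Compound 2 `COc1ccc(N2C(=O)N(Cc3ccccc3)c3ccccc3S2(=O)=O)cc1OC` gives 2000 nM in this assay.
Compound 3 `COc1cc(N2C(=O)N(Cc3c(F)cc(F)cc3F)c3ccccc3S2(=O)=O)cc(OC)n1` gives 15.9 nM in this assay.

Compound 2 shows the highest number of the three, with compound 1 nearest and compound 3 furthest from it. Compound 4 `COc1ccc(N2C(=O)N(Cc3c(F)cc(C)cc3Cl)c3ccccc3S2(=O)=O)cc1OC` differs from compound 2 in one place: 2-chloro-6-fluoro-4-methylphenyl in place of phenyl on a saturated chain carbon bound to an amide-type nitrogen in a ring. Among the measured compounds shown here, the only step that bears on this is a 32-fold higher number from compound 1 to compound 2 (1.50 log units; beyond the scatter), in which a substituted benzyl group was replaced by plain benzyl and the number rose sharply. Compound 4 goes the other way, restoring a substituted benzyl group, so a large drop beyond the scatter is expected in this assay. Compound 4 is therefore estimated at 60 nM, within 15 nM to 250 nM, which would mean an expected step of a 33-fold lower number from compound 2 to compound 4 (1.52 log units; beyond the scatter).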

Compound 4, inhibition constant: 6.31 nM
Beside the measured number, compound 4's estimate is 9.5-fold (0.98 log units) above it; measured number below the stated range.
By their numbers in this assay, from the lowest: compound 4; then compound 3; then compound 1; then compound 2.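

In this assay, going from benzyl to 2-chloro-6-fluoro-4-methylbenzyl gives a 320-fold lower number from compound 2 to compound 4 (2.50 log units; beyond the scatter) and so extends what substitution at this place can do. The choice of substituents matters as well as their presence, since 2-chloro-6-fluoro-4-methylphenyl in place of 2,4-difluoro-6-methoxyphenyl still gives a 10-fold lower number from compound 1 to compound 4 (1.00 log units; beyond the scatter) on the same core. Nothing available accounts for either step.

Going by these compounds, it remains open whether the chlorine, the fluorine or the methyl carries the gain. Also open, on these data alone, is whether an amine or a carboxylic acid on this ring would be accepted at this place.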